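The source may hold more compounds than are shown below. What is called first, only, known or untested is meant among the compounds shown, and "the series" means these compounds.

Measured so far in a functional assay on MOLT-4 cells (Homo sapiens) for antiproliferative activity; on this read-out lower numbers stand for stronger inhibition and higher numbers for weaker inhibition:
- compound 1 `COc1cc(C(=O)c2sc(-c3cccs3)cc2N)cc(OC)c1OC` gives 8.9 nM
- compound 2 `COc1cc(C(=O)c2sc(-c3ccc(Cl)cc3)cc2N)cc(OC)c1OC` gives 77 nM
- compound 3 `COc1cc(C(=O)c2sc(-c3ccc(I)cc3)cc2N)cc(OC)c1OC` gives 190 nM

Compound 3 holds the highest number of the three, separated from compound 2 by a 2.5-fold higher number from compound 2 to compound 3 (0.39 log units; beyond the scatter) and from compound 1 by a 21-fold higher number from compound 1 to compound 3 (1.33 log units; beyond the scatter). Compound 4 `COc1cc(C(=O)c2sc(-c3ccc(Br)cc3)cc2N)cc(OC)c1OC` is not yet measured; it differs from compound 3 in one place: bromo in place of iodo on an aromatic carbon.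

Of the measured steps, only a 2.5-fold higher number from compound 2 to compound 3 (0.39 log units; beyond the scatter) bears directly on this change, since it swaps one halogen for another at the same place on the ring; the steps of an 8.7-fold higher number from compound 1 to compound 2 (0.94 log units; beyond the scatter) and a 21-fold higher number from compound 1 to compound 3 (1.33 log units; beyond the scatter) exchange the whole ring and say nothing about the halogen alone. Compound 4 carries a halogen at the place where compound 2 carries chloro and compound 3 carries iodo, so the expected number lies between the values of compound 2 and compound 3, and the step of a 1.6-fold lower number from compound 3 to compound 4 (0.20 log units; within the scatter) is expected to be small and downward, close to the scatter. For compound 4 the estimate in this assay is 120 nM, within 50 nM to 300 nM.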

Compound 4, half-maximal inhibitory concentration: 92 nM
Estimate against measurement, compound 4: 1.3-fold (0.12 log units) above; the range from low to high includes it.
By their numbers in this assay, from the lowest: compound 1; then compounds 2 and 4 (each within the scatter of the next); then compound 3.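

In this assay, a 2.1-fold lower number from compound 3 to compound 4 (0.31 log units; beyond the scatter) shows that the iodo group can be told apart from bromo at this place, on the six-membered aromatic ring, whereas a 1.2-fold higher number from compound 2 to compound 4 (0.08 log units; within the scatter) leaves bromo and chloro within the scatter of each other. Among the three halogens shown, only the iodo of compound 3 therefore stands apart, and the chloro and bromo compounds form a single level rather than a graded series. With a 10-fold higher number from compound 1 to compound 4 (1.01 log units; beyond the scatter), the 4-bromophenyl group also remains well separated from the thiophen-2-yl group, and no measurement on hand explains any of these differences.

Still open, on these data alone, is how fluoro, methoxy or an amine would read at this place. Also open, as far as these compounds go, is whether an unsubstituted phenyl would sit nearer compound 1 or the halogenated compounds.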